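A few compounds are considered here, and "the series" means these few. Any claim that something is new, unique, unknown or untested is made for them only; others in the source may bear on it.

Compound 2 `CCCCNc1nc(N)nc2cccc(OCc3ccccc3OC)c12` stands in an ADME assay on HEK293 cells for agonist activity at Toll-like receptor 8 (Homo sapiens), read by a luciferase reporter, with a stated time of 6 h (on this read-out higher numbers stand for an effect only at larger amounts of compound and lower numbers for an effect already at smaller amounts), at a limit of the assay, > 25 uM, which is the limit (the limit of > 25 uM in this assay, at which 1 of the 2 values shown sits). Compound 1 `CCCCNc1nc(N)nc2cccc(OCc3ccccc3)c12` in this assay gives 1.66 uM. Within the data shown here, the one measured step, an at least 15-fold higher number from compound 1 to compound 2 (1.17 log units; beyond the scatter), accompanies methoxy in place of hydrogen on an aromatic carbon. Compound 3 `CCCCNc1nc(N)nc2cccc(OCc3ccccn3)c12` has not yet been measured in this assay. The change from compound 2 to compound 3 is pyridin-2-yl in place of 2-methoxyphenyl on a saturated chain carbon bound to an oxygen on an aromatic ring. The methoxy that set compound 2 apart from compound 1 is absent in compound 3, so the measured step bears on this one in reverse: the large rise seen in an at least 15-fold higher number from compound 1 to compound 2 (1.17 log units; beyond the scatter) is expected to be undone. Among the measured compounds shown here, the ring with one hetero atom in place of the ring of carbon only has no measured counterpart here, and its contribution is unknown. The step is expected to be a large fall in number, an at least 8.3-fold lower number from compound 2 to compound 3 (0.92 log units; beyond the scatter), bringing compound 3 near compound 1. For compound 3 in this assay the expected value is 3 uM, with a range from 1 uM to 12 uM.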

Compound 3, minimum effective concentration: 18.5 uM
Estimate against measurement, compound 3: 6.2-fold (0.79 log units) below, outside the stated range (above it).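

In this assay, the group on the saturated chain carbon bound to an oxygen on an aromatic ring now shows a second large change, with pyridin-2-yl in place of phenyl giving an 11-fold higher number from compound 1 to compound 3 (1.05 log units; beyond the scatter). Among these compounds, with no methoxy present in compound 3, the higher number seen for compound 2 is therefore not a peculiarity of that one group: among the three compounds, phenyl is the only group that gives a low number, and neither replacement goes against this. Compound 2 gives > 25 uM, which is a limit of the assay and not a number, and the comparison with compound 3 reads an at least 1.3-fold lower number from compound 2 to compound 3 (0.13 log units; that floor lies within the scatter), so no order between these two can be stated: the limit of > 25 uM in this assay, at which 1 of the 3 values shown sits.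

Still open, going by these compounds, is whether the rise with pyridin-2-yl follows the hetero atom as such or its place in the ring, a question that pyridin-3-yl or pyridin-4-yl would address. Also open, on these data alone, is whether any group on the phenyl ring is accepted at all, which a smaller one such as 4-fluorophenyl or 4-methylphenyl on the shared core would test.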